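The source may hold more compounds than are shown below. What is called first, only, known or untested is meant among the compounds shown, and "the series" means these compounds.

Of the compounds shown here, two have been measured so far in an ADME assay on MDCK cells (Canis lupus familiaris) for permeability, in the apical to basolateral direction; on this read-out lower numbers stand for lower permeability and higher numbers for higher permeability. Compound 1 `CC(C)n1cc(C(N)=O)c2cnc(Nc3ccnc(-c4cnn(S(=O)(=O)C5CC5)c4)n3)cc21` gives 4.5 10^-6 cm/s, while compound 2 `CC(C)n1nc(N)c2cnc(Nc3ccnc(-c4cnn(S(=O)(=O)C5CC5)c4)n3)cc21` gives 16 10^-6 cm/s, the higher of the two numbers, and the gap between them lies beyond the usual scatter. Compound 3 `CC(C)n1nc(N2CC(CO)C2)c2cnc(Nc3ccnc(-c4cnn(S(=O)(=O)C5CC5)c4)n3)cc21` differs from compound 2 in a single place: 3-(hydroxymethyl)azetidin-1-yl in place of amino on an aromatic carbon. Among the compounds with values here, no pair of measured compounds shows this kind of change, so no step can be read off for it. The step of a 1.6-fold lower number from compound 2 to compound 3 (0.20 log units; within the scatter) is expected to be a modest fall, possibly still within the scatter. For compound 3 the estimate is 10 10^-6 cm/s, in a range from 4 10^-6 cm/s to 22 10^-6 cm/s.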

Compound 3, apparent permeability in the MDCK assay: 8.1 10^-6 cm/s
The estimate for compound 3 lay 1.2-fold (0.09 log units) above the measured number; low and high end bracket the measured number.
By their numbers in the MDCK assay, from the lowest: compounds 1, 3 and 2 (each within the scatter of the next, the first and the last beyond it).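

This position on the five-membered aromatic ring accepts a much larger group than amino: in the MDCK assay, 3-(hydroxymethyl)azetidin-1-yl, with 6 heavy atoms and a four-membered ring, gives a 2.0-fold lower number from compound 2 to compound 3 (0.30 log units; within the scatter), with compound 2 at 16 10^-6 cm/s and compound 3 at 8.1 10^-6 cm/s. In a physicochemical assay for solubility, in phosphate buffer, measured as kinetic solubility, with a stated time of 24 h, at pH 7.4, tested at 100 uM (on this read-out lower numbers stand for lower solubility and higher numbers for higher solubility), the same change gives a 1.5-fold higher number from compound 2 to compound 3 (0.18 log units; within the scatter), with compound 2 at 2000 nM and compound 3 at 3000 nM, so neither read-out separates the two compounds. No measurement here offers an explanation for either step.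

From the compounds shown here alone, it remains open whether the hydroxymethyl matters, which a plain azetidin-1-yl could test. A longer chain or a carboxylic acid at this position could also behave differently.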